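This account rests on a few compounds, and the source may have more. Where it says the series, first, only, none or still open, it means among the compounds named here.

Measured compounds in a functional assay on MDA-MB-468 cells (Homo sapiens) for inhibition, read by sulforhodamine B assay, with a stated time of 48 h; on this read-out higher numbers stand for weaker inhibition of growth and lower numbers for stronger inhibition of growth:
Compound 1, `COc1ccc(-c2cc(/C=C/C(=O)c3ccc(N)cc3)[nH]n2)cc1`, gives 430 nM.
Compound 2, `COc1cc(-c2cc(/C=C/C(=O)c3ccc(Cl)c(Cl)c3)[nH]n2)cc(OC)c1OC`, gives 1980 nM.

Of these two numbers, compound 2 stands at the higher one; its nearest neighbour is compound 1, which sits at a lower number by a gap that lies beyond the usual scatter of repeated measurements. Among the measured compounds shown here, compound 2 and compound 1 differ in more than one place, so no single step between them can be read from their two values.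

Compound 3, `COc1ccc(C(=O)/C=C/c2cc(-c3cc(OC)c(OC)c(OC)c3)n[nH]2)cc1`, has not yet been measured. It differs from compound 2 in one place: 4-methoxyphenyl in place of 3,4-dichlorophenyl on a carbonyl carbon. For the measured compounds named here, no measured pair shows this exchange, so the size of the step rests on expectation alone. The account expects only a small change, not clearly beyond the scatter, with a slight lean toward a lower number. For compound 3 in this assay the estimate is 1300 nM, with a range from 450 nM to 4000 nM, which means an expected step of a 1.5-fold lower number from compound 2 to compound 3 (0.18 log units; within the scatter) from compound 2 to compound 3.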

Compound 3, concentration for 50% growth inhibition: 1290 nM
Estimate against measurement, compound 3: 1.0-fold (0.00 log units) above; low and high end bracket the measured number.
By their numbers in this assay, from the lowest: compound 1; then compounds 3 and 2 (each within the scatter of the next).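

In this assay, 4-methoxyphenyl in place of 3,4-dichlorophenyl on the carbonyl carbon gives a 1.5-fold lower number from compound 2 to compound 3 (0.19 log units; within the scatter), a step within the usual scatter of repeated measurements and the first that can be read for a change in one place. With the rest of the molecule held fixed, this read-out does not separate the two groups at this position, although the exchange removes both chlorine atoms and brings in a hydrogen-bond acceptor. Nothing available here bears on why the number stays within the scatter across this exchange.

The other pairs differ in more than one place, so no step can be read from them, and the value of compound 1 cannot be tied to the group on its carbonyl carbon alone. As far as these compounds go, it stays open whether a plain phenyl, a nitrile or a carboxylic acid at this position would move the number beyond the scatter, or whether the same exchange would give a similar step on a different core.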